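The compounds below may be only part of what the source reports. "The series", "measured", "known", "first", "only" and "open" are said of these compounds alone.

In a functional assay on HL-60 cells (Homo sapiens) for cytotoxicity, read by WST assay, with a stated time of 48 h (a higher number here means that more compound is needed for the effect, a lower number that less compound is needed), compound 1 `CCOc1ccccc1C[C@H]1COC[C@@H]1Cc1ccc(Cl)c(Cl)c1` gives 29000 nM while compound 2 `CCCCOc1ccccc1C[C@H]1COC[C@@H]1Cc1ccc(Cl)c(Cl)c1` gives 20000 nM and compound 3 `Fc1ccccc1C[C@H]1COC[C@@H]1Cc1ccc(Cl)c(Cl)c1` gives 51000 nM as its reading. Compound 3 cannot be told apart from compound 1, with a 1.8-fold higher number from compound 1 to compound 3 (0.25 log units; within the scatter) between them. It does separate from compound 2, with a 2.6-fold higher number from compound 2 to compound 3 (0.41 log units; beyond the scatter) as the only gap among the three that clears the scatter, whereas a 1.5-fold lower number from compound 1 to compound 2 (0.16 log units; within the scatter) does not.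

The remaining compound 4 `Cc1ccc(C[C@H]2COC[C@@H]2Cc2ccc(Cl)c(Cl)c2)cc1` carries 4-methylphenyl in place of 2-fluorophenyl on a saturated chain carbon bound to a saturated ring carbon. Going by the values given here, no measured step makes this exact change. The closest evidence is the pair of steps that link compound 3 to compound 1 and compound 2, in which fluoro is exchanged for another group on an aromatic carbon. Both are small, one within the scatter and the other modestly beyond it, and neither involves a methyl group. On that evidence the expected step is a 1.5-fold lower number from compound 3 to compound 4 (0.16 log units; within the scatter) and nothing clearly beyond the scatter is anticipated. For compound 4 the estimated value is 35000 nM with an expected range from 14000 nM to 80000 nM in this series.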

Compound 4, half-maximal effective concentration: 21000 nM
Compound 4: the middle estimate sits 1.7-fold (0.22 log units) above what was measured, within the range that was stated.
By their numbers in this assay, from the lowest: compounds 2, 4, 1 and 3 (each within the scatter of the next, the first and the last beyond it).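

In this assay, replacing 2-fluorophenyl with 4-methylphenyl on a saturated chain carbon bound to a saturated ring carbon gives a 2.4-fold lower number from compound 3 to compound 4 (0.39 log units; beyond the scatter). Going by these compounds alone, this is a modest step, but it shows that a group without oxygen can also move the number clear of the scatter from compound 3, whereas the earlier steps out of compound 3 led only to the ethoxy and butoxy compounds, and only the butoxy compound cleared the scatter. The names 2-fluorophenyl and 4-methylphenyl show that the substituent and its place on the phenyl ring differ together, so this single step cannot assign the shift to either one, and no measurement at hand accounts for it.

What the compounds shown leave open is whether the methyl group or its place on the ring matters here, a question that 2-methylphenyl and 4-fluorophenyl at this same position would separate. They also leave open how the number would respond to an amine or a carboxylic acid on this phenyl ring.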